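Swapping a Cyclopentyl for a Cyclopropylmethyl on the Amine

The compounds below may be only part of what the source reports. "The series", "measured", "known", "first", "only" and "open" are said of these compounds alone.

Of the compounds shown here, two sharing one core have been tested in a functional assay on the whole organism for inhibition, with Nicotiana tabacum as the target; on this read-out lower numbers stand for stronger inhibition and higher numbers for weaker inhibition. In this assay compound 1 `Cc1nc(Nc2ccc(Br)cc2)c2cc[nH]c2n1` gives 170000000 nM. Compound 2 `Cc1nc(NC2CCCC2)c2cc[nH]c2n1` gives 72400000 nM in this assay, the lower of the two numbers, and its gap to compound 1 lies beyond the usual scatter. Compound 3 `Cc1nc(NCC2CC2)c2cc[nH]c2n1` has not yet been measured. It differs from compound 2 in one place: cyclopropylmethyl in place of cyclopentyl on a nitrogen on an aromatic ring. Among the measured compounds shown here, no measured pair shows what this kind of swap does on this core, so neither the size nor the direction of the step can be read from the data. The step from compound 2 to compound 3 is expected to be small, most likely a 1.1-fold higher number from compound 2 to compound 3 (0.04 log units; within the scatter), and within the scatter in either direction. In this assay compound 3 is therefore estimated at 80000000 nM, with a range from 30000000 nM to 250000000 nM.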

Compound 3, half-maximal inhibitory concentration: 77600000 nM
Compound 3: the middle estimate sits 1.0-fold (0.01 log units) above what was measured; measured number inside the range.
By their numbers in this assay, from the lowest: compounds 2 and 3 (each within the scatter of the next); then compound 1.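

In this assay, among the compounds shown here, the first measured swap on this nitrogen, cyclopropylmethyl in place of cyclopentyl, gives a 1.1-fold higher number from compound 2 to compound 3 (0.03 log units; within the scatter). For the compounds shown here, this is the first direct look at a single change at this position: the numbers for these two compounds cannot be told apart, even though the five-membered ring gives way to a three-membered ring and the group has one heavy atom fewer. Nothing available explains why the two groups read alike, so the result describes the outcome without giving its cause.

Both groups contain only carbon and have no hydrogen-bond donors or acceptors, so this single pair says little about groups of a different kind. From the compounds shown here alone, it remains open whether a longer chain such as n-butyl, or a group carrying an amine or a carboxylic acid, would give a clearly different number on this nitrogen.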